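The source may report more compounds than this note shows. Statements on the series, on what has been measured and on what is new or still open speak of the compounds shown alone.

Compound 1 `Cc1cc(NNC(=O)Nc2cc(Cl)nc(Cl)c2)ncc1C#N` was tested in a functional assay on CHO cells for agonist activity at sphingosine 1-phosphate receptor 2 (Homo sapiens), read by fluorescence and calcium flux, with a stated time of 3 min; a lower number here means a stronger inhibitor, a higher number a weaker inhibitor. Compound 1 reached only the assay's limit, > 23000 nM, a boundary rather than a measured number. Compound 2 `CCOC(=O)c1cc(C)cc(NNC(=O)Nc2cc(Cl)nc(Cl)c2)n1` likewise returned only a limit, > 23000 nM. Both results sit at the limit of > 23000 nM in this assay, at which 2 of the 2 values shown sit, so compound 1 stands level with the only other compound shown, with no real number for either. Compound 3 `Cc1cc(NNC(=O)Nc2cc(Cl)nc(Cl)c2)ncc1-c1ccn(C)n1` differs from compound 1 by 1-methyl-1H-pyrazol-3-yl in place of cyano on an aromatic carbon. Compound 3 is expected to stay at the limit as well, with a step that the limit leaves unreadable from compound 1 to compound 3, nothing beyond the scatter. Compound 3 is therefore estimated at 30000 nM, between 8000 nM and 100000 nM.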

Compound 3, half-maximal inhibitory concentration: > 23000 nM
Compound 3: a limit, no number (the forecaster's own chance of this, stated with the estimate: 80%); the middle value is on the limit's open side.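

In this assay compound 3 gives only a limit, as does compound 1, so the step between them cannot be read. The compounds shown leave open whether any of them has a measurable potency.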